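This account rests on a few compounds, and the source may have more. Where it says the series, first, only, none or still open, it means among the compounds named here.

In a functional assay on HeLa cells (Homo sapiens) for antiproliferative activity, read by sulforhodamine B assay, with a stated time of 48 h (a lower number here means a stronger inhibitor, a higher number a weaker inhibitor), compound 1 (`COc1ccc(C(=O)/C=C\Nc2ccc(-c3nc4cc(OC)c(OC)c(OC)c4s3)cc2C)cc1O`) gives 11400 nM and sits level with compound 3 (`COc1ccc(C(=O)/C=C\Nc2ccc(-c3nc4cc(OC)c(OC)c(OC)c4s3)cc2C)cc1[N+](=O)[O-]`) at 13400 nM with a 1.2-fold higher number from compound 1 to compound 3 (0.07 log units; within the scatter) between them. Compound 2 (`COc1ccc(C(=O)/C=C\Nc2ccc(-c3nc4cc(OC)c(OC)c(OC)c4s3)cc2C)cc1F`) stands apart at 1200 nM with a 9.5-fold lower number from compound 1 to compound 2 (0.98 log units; beyond the scatter) for fluoro in place of hydroxy, and an 11-fold higher number from compound 2 to compound 3 (1.05 log units; beyond the scatter) for nitro in place of fluoro. Compound 4 (`COc1ccc(C(=O)/C=C\Nc2ccc(-c3nc4cc(OC)c(OC)c(OC)c4s3)cc2)cc1O`) has not been measured and differs from compound 1 as hydrogen in place of methyl on an aromatic carbon with hydrogen in place of methyl on an aromatic carbon. All three measured steps exchange the group that is hydroxy in compound 1 and leave the methyl untouched, so none of them tests this change. They give neither a size nor a direction for it, and no step beyond the scatter is expected in this assay on present evidence. The expected move is a 1.3-fold lower number from compound 1 to compound 4 (0.10 log units; within the scatter) and it carries wide uncertainty. Compound 4 is estimated at 9000 nM with an expected range from 2500 nM to 30000 nM in this measurement.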

Compound 4, half-maximal inhibitory concentration: 14100 nM
For compound 4 the middle estimate is 1.6-fold (0.19 log units) below the measured one; the range from low to high includes it.
By their numbers in this assay, from the lowest: compound 2; then compounds 1, 3 and 4 (each within the scatter of the next).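

In this assay the exchange of methyl for hydrogen on this aromatic carbon, ortho to a large group and meta to a large group, gives a 1.2-fold higher number from compound 1 to compound 4 (0.09 log units; within the scatter) and so stays within the scatter. Within the data shown here, this is the first reading at this position, as the earlier steps all exchanged the hydroxy group, and it shows that with the hydroxy group in place, the methyl can give way to hydrogen with no difference beyond the scatter. Nothing available explains this result.

As far as these compounds go, whether the same exchange holds alongside the fluoro group of compound 2 remains open, since one pair in a single series cannot settle it. Also open, from the compounds shown here alone, is what an ethyl group, a chloro atom or an amine would do on this carbon.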